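Swapping a Side Chain for Furan-3-yl

This account rests on a few compounds, and the source may have more. Where it says the series, first, only, none or still open, it means among the compounds named here.

Two esters sharing one core have been measured in a functional assay on DU-145 cells (Homo sapiens) for cytotoxicity, read by MTT assay; a lower number here means a stronger inhibitor, a higher number a weaker inhibitor. Compound 1 (`CC(C)=CC[C@@H](OC(=O)c1ccco1)C1=CC(=O)c2c(O)ccc(O)c2C1=O`) gives > 100000 nM, which is a limit of the assay and not a number. Compound 2 (`CC(C)=CC[C@@H](OC(=O)CC(C)(O)c1ccccc1)C1=CC(=O)c2c(O)ccc(O)c2C1=O`) gives > 100000 nM, which is also a limit and not a number. Both results stand at the same point: the limit of > 100000 nM in this assay, at which 2 of the 2 values shown sit. Among the measured compounds shown here, the one measured step, a step that the two limits leave unreadable from compound 1 to compound 2, therefore offers no size to carry forward.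

Compound 3 (`CC(C)=CC[C@@H](OC(=O)c1ccoc1)C1=CC(=O)c2c(O)ccc(O)c2C1=O`) follows from compound 2 through (furan-3-yl in place of 2-hydroxy-2-phenylpropyl on a carbonyl carbon). The closest guide is compound 1 at > 100000 nM, again a limit, since it carries furan-2-yl where compound 3 carries furan-3-yl. In this assay, the expected change, a number no higher from compound 2 to compound 3 (the limit leaves the size open), is none beyond the scatter. For compound 3 the estimated value is 100000 nM, with an expected range from 30000 nM to 300000 nM.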

Compound 3, half-maximal inhibitory concentration: > 100000 nM
Compound 3: no number, only a limit; the forecaster's own chance of this, stated with the estimate: 70%; the middle value lies on the limit itself.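

In this assay compound 3 gives > 100000 nM as a limit and not a number. Among the compounds shown here, all three results are limits, and no step among compound 1, compound 2 and compound 3 can be read. From the compounds shown here alone, how the group on the carbonyl carbon changes cytotoxicity stays open.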